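The source may hold more compounds than are shown below. What is called first, only, known or untested is meant among the compounds shown, and "the series" means these compounds.

In an assay for activation of interferon regulatory factor 3 (Homo sapiens), read by a luciferase reporter, with a stated time of 20 h (a lower number here means that less compound is needed, a higher number that more compound is needed for the effect), three compounds sharing one core have been measured, each differing only in the aromatic group attached to a carbonyl carbon. Compound 1 `COc1cc(C(N)=O)cc2nc(NC(=O)c3nccc4ccccc34)n(CCCNC(=O)OCc3ccccc3)c12` carries an isoquinolin-1-yl group there. In this assay compound 1 gives > 100000 nM, which is a limit of the assay rather than a number. Compound 2 `COc1cc(C(N)=O)cc2nc(NC(=O)c3ccccn3)n(CCCNC(=O)OCc3ccccc3)c12` carries a pyridin-2-yl group instead. In this assay compound 2 gives > 100000 nM, again a limit. Compound 3 `COc1cc(C(N)=O)cc2nc(NC(=O)c3cccnn3)n(CCCNC(=O)OCc3ccccc3)c12` carries a pyridazin-3-yl group. In this assay compound 3 gives > 100000 nM, also a limit. Among the compounds with values here, because all three values sit at the limit of > 100000 nM in this assay, at which 3 of the 3 values shown sit, no step between them can be read: a step that the two limits leave unreadable from compound 1 to compound 2, a step that the two limits leave unreadable from compound 1 to compound 3 and a step that the two limits leave unreadable from compound 2 to compound 3 all remain of unknown size. Compound 3 thus stands at the limit, indistinguishable from the other two.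

Compound 4 `COc1cc(C(N)=O)cc2nc(NC(=O)c3cc4ccccc4n3C)n(CCCNC(=O)OCc3ccccc3)c12` differs from compound 3 in one place: 1-methyl-1H-indol-2-yl in place of pyridazin-3-yl on a carbonyl carbon. Within the data shown here, none of the measured steps bears on this change: every one of them is unreadable, and none brings in a bicyclic group of this kind. Among the measured compounds shown here, the only guide is that the three known values are all limits. The step of an at least 1.2-fold lower number from compound 3 to compound 4 (0.09 log units; that floor lies within the scatter) is therefore expected to be small or to stay unreadable. Compound 4 is estimated at 80000 nM, within 8000 nM to 300000 nM, with a real chance that this assay again reports only a limit.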

Compound 4, half-maximal effective concentration: > 100000 nM
Compound 4 ended at the assay's limit; the forecaster's own chance of this, stated with the estimate: 70%; middle value at least 1.2-fold (0.09 log units) away from the limit.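

In this assay compound 4 gives > 100000 nM, which is a limit of the assay and not a number. Within the data shown here, no step among compound 1, compound 2, compound 3 and compound 4 can be read, because all of them share one limit: the limit of > 100000 nM in this assay, at which 4 of the 4 values shown sit. The compounds shown leave open whether any aromatic group on this carbonyl carbon gives a measurable value, and how these four groups rank.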